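The compounds below may be only part of what the source reports. "The series", "measured", "known", "first", "only" and "open" are said of these compounds alone.

Two compounds share one core and differ only in the group carried on an amine nitrogen in a ring. Compound 1 `CCCCN1CCN(CCC(=O)Nc2nc3c(C)cccc3s2)CC1` gives 1200 nM in an assay on membranes from liver for displacement of a labelled ligand from Sigma intracellular receptor 2 (Rattus norvegicus), read by scintillation counting, with a stated time of 120 min; on this read-out lower numbers stand for stronger inhibition and higher numbers for weaker inhibition. Going by the values given here, compound 2 `Cc1cccc2sc(NC(=O)CCN3CCN(C4CCCCC4)CC3)nc12` gives 233 nM in this assay, the lower of the two numbers; the single step measured so far, a 5.2-fold lower number from compound 1 to compound 2 (0.71 log units; beyond the scatter), came from putting cyclohexyl in place of butyl on that ring nitrogen. Compound 3 `Cc1cccc2sc(NC(=O)CCN3CCN(CCN(C(C)C)C(C)C)CC3)nc12` is the next variation: 2-(diisopropylamino)ethyl in place of cyclohexyl on an amine nitrogen in a ring. Among the compounds with values here, only that one step bears on the new change, and only loosely: it shows that the group on that ring nitrogen moves the number beyond the scatter, but the entering group is neither a ring nor a plain chain, and no measured pair tests an added acceptor there. A modest step in this assay is therefore expected, direction uncertain, so compound 3 is estimated at 300 nM, within 80 nM to 1100 nM, meaning a 1.3-fold higher number from compound 2 to compound 3 (0.11 log units; within the scatter).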

Compound 3, inhibition constant: 121 nM
Beside the measured number, compound 3's estimate is 2.5-fold (0.39 log units) above it, within the range that was stated.
By their numbers in this assay, from the lowest: compounds 3 and 2 (each within the scatter of the next); then compound 1.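

In this assay, replacing cyclohexyl with the open 2-(diisopropylamino)ethyl group, which adds a hydrogen-bond acceptor, gives a 1.9-fold lower number from compound 2 to compound 3 (0.28 log units; within the scatter) and so leaves the two compounds indistinguishable, showing that this ring nitrogen can carry a ring-free group with more heavy atoms and a further nitrogen. The comparison with the butyl compound gives a 9.9-fold lower number from compound 1 to compound 3 (1.00 log units; beyond the scatter) and is beyond the scatter, so an open chain on this nitrogen does not by itself bring a weak number, and the kind of chain matters. Nothing available explains why these numbers differ.

Going by these compounds, whether the added nitrogen matters stays open, since a plain hexyl chain at this position would be needed to separate it from chain size alone. A smaller end group such as dimethylamino, or a ring amine such as piperidine, could also show how much the two isopropyl groups contribute.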